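A few compounds are considered here, and "the series" means these few. Any claim that something is new, unique, unknown or untested is made for them only; others in the source may bear on it.

Working notes on the series. All four compounds share one core and differ only in the group on an aromatic nitrogen. Compound 1 `CC(C)c1onc(-c2c(Cl)cccc2Cl)c1COc1ccc(-c2nc3ccc(C(=O)O)cc3n2CC2CC2)cc1` carries cyclopropylmethyl there; in an assay on HEK-293T cells for antagonist activity at vitamin D3 receptor (Homo sapiens), read by a luciferase reporter, with a stated time of 24 h (on this read-out higher numbers stand for weaker inhibition and lower numbers for stronger inhibition), compound 1 gives 2650 nM. Compound 2 `CC(=O)N1CCC(n2c(-c3ccc(OCc4c(-c5c(Cl)cccc5Cl)noc4C(C)C)cc3)nc3ccc(C(=O)O)cc32)CC1` carries 1-acetylpiperidin-4-yl, and in this assay compound 2 returns only > 10000 nM, a limit of the assay and not a number. Compound 3 `CC(C)c1onc(-c2c(Cl)cccc2Cl)c1COc1ccc(-c2nc3ccc(C(=O)O)cc3n2C2CCC2)cc1` carries cyclobutyl; in this assay compound 3 gives 1100 nM, the lower of the two numbers, with compound 1 nearest. The measured steps are a 2.4-fold lower number from compound 1 to compound 3 (0.38 log units; beyond the scatter), an at least 3.7-fold higher number from compound 1 to compound 2 (0.57 log units; beyond the scatter) and an at least 9.0-fold lower number from compound 2 to compound 3 (0.95 log units; beyond the scatter), the latter two resting on (the limit of > 10000 nM in this assay, at which 1 of the 3 values shown sits).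

Compound 4 `CC(C)c1onc(-c2c(Cl)cccc2Cl)c1COc1ccc(-c2nc3ccc(C(=O)O)cc3n2C2CCCCCC2)cc1` differs from compound 3 by cycloheptyl in place of cyclobutyl on an aromatic nitrogen. Among the compounds with values here, of the measured steps, only the cyclopropylmethyl-to-cyclobutyl step concerns a small carbocycle on this nitrogen, and it was modest; no measured step covers a seven-membered ring, and the one step toward a larger group, 1>2, rose but involved a group of a different kind. A step of a 1.8-fold higher number from compound 3 to compound 4 (0.26 log units; within the scatter) is therefore expected, a modest rise or none beyond the scatter. Compound 4 is estimated at 2000 nM, between 600 nM and 7000 nM.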

Compound 4, half-maximal inhibitory concentration: 921 nM
Estimate against measurement, compound 4: 2.2-fold (0.34 log units) above, within the range that was stated.
By their numbers in this assay, from the lowest: compounds 4 and 3 (each within the scatter of the next); then compound 1. At a limit, above all of these: compound 2.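

Cyclobutyl and cycloheptyl on the aromatic nitrogen are not told apart in this assay: a 1.2-fold lower number from compound 3 to compound 4 (0.08 log units; within the scatter). Within the data shown here, this extends the plain carbon rings at this position well past the size the earlier compounds covered, and the larger ring also stands clear of cyclopropylmethyl: a 2.9-fold lower number from compound 1 to compound 4 (0.46 log units; beyond the scatter). A larger ring of carbon only does not repeat the loss seen with 1-acetylpiperidin-4-yl, an at least 10-fold lower number from compound 2 to compound 4 (1.03 log units; beyond the scatter), and that step rests on a limit and not a number: the limit of > 10000 nM in this assay, at which 1 of the 4 values shown sits.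

The compounds shown leave open whether that loss belongs to the acetyl group or to the ring nitrogen, a question that a free piperidin-4-yl amine or a tetrahydropyran-4-yl group would address. Also open, from the compounds shown here alone, is whether a ring is needed on this nitrogen at all, as against an open chain such as heptyl.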